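The compounds below may be only part of what the source reports. "The series", "measured", "known", "first", "only" and "open" are said of these compounds alone.

Measured so far:
compound 1 `CCC(C(=O)N1CCN(c2cccc(C(F)(F)F)c2)CC1)N1C(=O)CC(C)C1=O` — 41.2 mg/kg
compound 2 `CC1CC(=O)N(CC(=O)N2CCN(c3cccc(C(F)(F)F)c3)CC2)C1=O` — 52.3 mg/kg

In a functional assay on the whole organism (strain Swiss) with Mus musculus as the target, with a stated time of 0.5 h (on this read-out lower numbers stand for an effect already at smaller amounts and higher numbers for an effect only at larger amounts of compound), compound 2 gives the higher of the two numbers, though its gap to compound 1 is within the scatter. Compound 3 `CC1CC(=O)N(C(C)C(=O)N2CCN(c3cccc(C(F)(F)F)c3)CC2)C1=O` has not yet been measured; it differs from compound 2 by methyl in place of hydrogen on a saturated chain carbon bound to an amide-type nitrogen in a ring and a carbonyl carbon. Among the compounds with values here, the one step that bears on this is a 1.3-fold higher number from compound 1 to compound 2 (0.10 log units; within the scatter), which went the other way, from ethyl to hydrogen, and stayed within the scatter. A change of similar size, if any, is therefore expected here, with no step beyond the scatter foreseen a 1.2-fold lower number from compound 2 to compound 3 (0.07 log units; within the scatter). Compound 3 is estimated at 45 mg/kg, in the range 25 mg/kg to 80 mg/kg.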

Compound 3, dose for half-maximal effect: 16.8 mg/kg
For compound 3 the middle estimate is 2.7-fold (0.43 log units) above the measured one; the whole stated range lies above it.
By their numbers in this assay, from the lowest: compound 3; then compounds 1 and 2 (each within the scatter of the next).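

In this assay, within the data shown here, methyl in place of hydrogen on this saturated chain carbon gives a 3.1-fold lower number from compound 2 to compound 3 (0.49 log units; beyond the scatter), the first step beyond the scatter, so the position does respond to substitution. Going from ethyl to methyl gives a 2.5-fold lower number from compound 1 to compound 3 (0.39 log units; beyond the scatter), while ethyl and hydrogen lie within the scatter of each other, so the numbers do not run in one direction from hydrogen through methyl to ethyl. Nothing given here explains this.

Left open is how a propyl chain or a hydroxymethyl group on this carbon would compare with methyl.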